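Trifluoromethyl for methyl on the aryl urea series

This account rests on a few compounds, and the source may have more. Where it says the series, first, only, none or still open, it means among the compounds named here.

Measured compounds:
Compound 1, `Cc1cccc(NC(=O)N[C@H](C)c2ccccc2)c1`: 98%
Compound 2, `Cc1cccc(NC(=O)N[C@@H](C)c2ccccc2)c1`: 100%
Compound 3, `CCc1ccccc1NC(=O)N[C@@H](C)c1ccccc1`: 100%

In an ADME assay on the whole organism with Oryza sativa as the target, tested at 1 uM (on this read-out higher numbers stand for a weaker effect at the one concentration tested and lower numbers for a stronger effect), compound 2 gives 100%. Compound 2 stands level with compound 3 at the digits shown, and within the scatter of compound 1. Among the compounds with values here, the only single-point step among the measured compounds is a number 2 percentage points higher from compound 1 to compound 2 (within the scatter), which rests on (the fact that compounds 1 and 2 differ only in the configuration as drawn); the two compounds are the same in every atom and bond. All three measured values sit at the top end of the scale, where the effect at the single concentration is weakest.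

The next compound, compound 4, `C[C@H](NC(=O)Nc1cccc(C(F)(F)F)c1)c1ccccc1`, differs from compound 2 in one place: trifluoromethyl in place of methyl on an aromatic carbon

No measured step in this series changes the substituent on that aromatic ring, so nothing shown bears directly on this replacement. Within the data shown here, the one measured step lies within the scatter, and the three values cluster without any spread beyond it. A step of a number 3 percentage points lower from compound 2 to compound 4 (within the scatter) is expected, that is, none beyond the scatter, with the read-out remaining near the top of the scale. Compound 4 is therefore estimated at 97%, between 85% and 100%.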

Compound 4, a percentage reported as activity, at one concentration (the size of the read-out at that concentration, not a potency): 93%
For compound 4 the middle estimate is 4 percentage points above the measured one; measured number inside the range.
By their numbers in this assay, from the lowest: compounds 4, 1, 2 and 3 (each within the scatter of the next).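

Trifluoromethyl in place of methyl on an aromatic carbon gives the first reading for a change of substituent at this position: in this assay the replacement reads as a number 7 percentage points lower from compound 2 to compound 4 (within the scatter) and so stays inside the usual variation. Four heavy atoms in place of one, with no hydrogen-bond donor or acceptor added, therefore do not separate compound 4 from compound 2 on this read-out. Nothing among the evidence at hand bears on this replacement, which rests on a single pair.

On these data alone, whether an amine, a carboxylic acid or a longer chain at this place would move the read-out beyond the scatter stays open. Also open, as far as these compounds go, is whether trifluoromethyl would read the same with the stereocentre drawn as in compound 1.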